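A few compounds are considered here, and "the series" means these few. Any claim that something is new, unique, unknown or untested is made for them only; others in the source may bear on it.

Compound 1 `Cc1csc(N)c1C(=O)c1ccc(Cl)cc1`, compound 2 `Nc1sc(-c2ccccc2)c(-c2ccccc2)c1C(=O)c1ccc(Cl)cc1` and compound 3 `CC(C)(C)Cc1c(-c2cccnc2)sc(N)c1C(=O)c1ccc(Cl)cc1` share one core and have been tested in an assay on CHO cells for displacement of a labelled ligand from adenosine receptor A1 (Homo sapiens), read by scintillation counting, tested at 10 uM; on this read-out higher numbers stand for more inhibition at the one concentration tested (going by the name of the read-out) and lower numbers for less inhibition. Compound 1 gives 1%, compound 2 gives 1% and compound 3 gives 1% in this assay, so all three stand level at the digits shown and within the scatter of one another. Compound 4 `COc1cccc(-c2sc(N)c(C(=O)c3ccc(Cl)cc3)c2CC(C)(C)C)c1` has not been measured. It differs from compound 3 by 3-methoxyphenyl in place of pyridin-3-yl on an aromatic carbon. Going by the values given here, no step between measured compounds covers a change of this kind, and none of the measured compounds departs from the same low level, so no step beyond the scatter is expected in this assay. The step is estimated at a number 1 percentage points higher from compound 3 to compound 4 (within the scatter). For compound 4 the expected value is 2%, with a range of -6% to 12%.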

Compound 4, a percentage reported as inhibition, at one concentration (the size of the read-out at that concentration, not a potency): 1%
Estimate against measurement, compound 4: 1 percentage points above, and the stated range covers the measured number.
By their numbers in this assay, from the lowest: compounds 1, 2, 3 and 4 (each within the scatter of the next).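

In this assay, 3-methoxyphenyl in place of pyridin-3-yl on the aromatic carbon next to the ring sulfur, with the neopentyl group kept, gives no change at the digits printed from compound 3 to compound 4 (within the scatter). At this position, then, a carbon-only aromatic ring bearing a methoxy group and an aromatic ring with one hetero atom read alike, both at the low level shared by the series. Nothing at hand offers a reason for this flat result.

As far as these compounds go, whether any group at this position lifts the read-out stays open. A carboxylic acid or an aminomethyl group here, or a longer chain in place of neopentyl, could still show this.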